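The source may hold more compounds than are shown below. What is called first, only, known or untested is meant among the compounds shown, and "the series" means these compounds.

Measured so far in an assay on a protein complex for inhibition of CDK8/Cyclin C (Homo sapiens), with a stated time of 1 h, tested at 10 uM; on this read-out lower numbers stand for less inhibition and higher numbers for more inhibition at the one concentration tested (going by the name of the read-out):
compound 1, `CC(C)[C@@H](NC(=O)/C=C/c1ccncc1-c1ccc2ccccc2c1)C(=O)O`, gives 77%
compound 2, `CNC(=O)/C=C/c1ccncc1-c1ccc2[nH]ccc2c1`, gives 100%
compound 3, `Cn1ncc2cc(-c3cnccc3/C=C/C(=O)N3CCOCC3)ccc21`, gives 95%

Compound 1 stands lowest of the three numbers in this assay. Its nearest neighbour is compound 3, whose number sits above it by a gap beyond the usual scatter; compound 2 is furthest, again beyond the scatter. Going by the values given here, compounds 2 and 3 each differ from compound 1 in more than one place, so no single step between measured compounds can be read off. Among the compounds with values here, their values show only that the two compounds carrying a small amide and no acid sit higher than compound 1.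

Compound 4, `CN(C)C(=O)/C=C/c1ccncc1-c1ccc2ccccc2c1`, keeps everything in compound 1 except one change: dimethylamino in place of (1-carboxy-2-methylpropyl)amino on a carbonyl carbon. This change removes the acid and the stereocentre and leaves a small amide, as in compound 2 and compound 3, while the rest of compound 1 is unchanged.

Within the data shown here, no measured step covers this exact change. The expectation rests on the higher numbers of compound 2 and compound 3 in this assay, which suggest that a small amide is compatible with strong inhibition. Compound 4 is therefore expected to move upward from compound 1 by a step beyond the scatter, a number 13 percentage points higher from compound 1 to compound 4 (beyond the scatter). Compound 4 is estimated at 90%, within a range from 72% to 100%.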

Compound 4, a percentage reported as inhibition, at one concentration (the size of the read-out at that concentration, not a potency): 100%
Beside the measured number, compound 4's estimate is 10 percentage points below it; low and high end bracket the measured number.
By their numbers in this assay, from the lowest: compound 1; then compounds 3, 2 and 4 (each within the scatter of the next).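

In this assay, the series now has its first comparison that differs in one place, and it runs a number 23 percentage points higher from compound 1 to compound 4 (beyond the scatter) with dimethylamino in place of (1-carboxy-2-methylpropyl)amino on a carbonyl carbon. At this position, the (1-carboxy-2-methylpropyl)amino group, with its defined stereocentre and 2 hydrogen-bond donors, is therefore not required for strong inhibition at the one concentration tested, and going from 8 heavy atoms to 3 here raises the number rather than lowering it. Nothing measured for this pair offers an explanation for the step.

On these data alone, the step removes the carboxylic acid, the stereocentre and the amide hydrogen together, so it remains open which of these matters; a methyl ester in place of the carboxylic acid, or a longer chain ending in an amine on the same carbonyl carbon, would begin to separate them. As far as these compounds go, compound 4 gives 100% at a single concentration, which is not a potency, so how far the dimethylamino amide improves on compound 1 in potency also remains open.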